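Shortening the hydroxyalkyl ether arm of compound 2

The source may hold more compounds than are shown below. What is called first, only, known or untested is meant among the compounds shown, and "the series" means these compounds.

Compound 2 `CCC(O)(CC)COc1ccc(C(CC)(CC)c2ccc(OCC(CO)CO)c(C)c2)cc1C` and compound 1 `CCC(O)(CC)COc1ccc(C(CC)(CC)c2ccc(OC[C@@H](O)CO)c(C)c2)cc1C` share a core and differ only in one ether arm. In an assay on HOS cells for agonist activity at vitamin D3 receptor (Homo sapiens), read by a luciferase reporter (a higher number here means that more compound is needed for the effect, a lower number that less compound is needed), compound 2 gives 9.26 nM, the lower of the two numbers, while compound 1 gives 18 nM; the step of a 1.9-fold lower number from compound 1 to compound 2 (0.29 log units; within the scatter) is within the scatter, so the two cannot be told apart. Compound 3 `CCC(CC)(c1ccc(OCCC(C)(C)O)c(C)c1)c1ccc(OCC(CO)CO)c(C)c1` keeps the arm of compound 2 and alters the other one: 2-hydroxy-2-methylpropyl in place of 1-ethyl-1-hydroxypropyl on a saturated chain carbon bound to an oxygen on an aromatic ring. No measured pair touches this arm, so nothing shown bears directly on the change; the one measured step concerns the opposite end of the molecule. With a group of similar size and the same count of donors and acceptors, the half-maximal effective concentration of compound 3 is expected to stay close to that of compound 2, a step of a 1.6-fold higher number from compound 2 to compound 3 (0.21 log units; within the scatter). Compound 3 is therefore estimated at 15 nM, with a range of 4 nM to 60 nM.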

Compound 3, half-maximal effective concentration: 76.9 nM
The estimate for compound 3 lay 5.1-fold (0.71 log units) below the measured number; the measured number lies above the stated range.
By their numbers in this assay, from the lowest: compounds 2 and 1 (each within the scatter of the next); then compound 3.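

In this assay, within the data shown here, the swap of 1-ethyl-1-hydroxypropyl for 2-hydroxy-2-methylpropyl gives an 8.3-fold higher number from compound 2 to compound 3 (0.92 log units; beyond the scatter) and so shows that this ether arm affects the result, whereas the only earlier step, at the other arm, stayed within the scatter. The number moves even though the counts of hydrogen-bond donors and acceptors stay the same, so those counts alone do not describe what matters at this position. No available evidence explains this step.

Read one bond further out, the change from 2-ethyl-2-hydroxybutyl to 3-hydroxy-3-methylbutyl alters both the length of the chain and the alkyl groups on the hydroxyl-bearing carbon, and this single pair cannot separate the two. Going by these compounds, a 3-ethyl-3-hydroxypentyl arm would bear on that question, while the effect of an amine in place of the hydroxyl also remains open.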